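The source may hold more compounds than are shown below. What is called first, only, known or untested is meant among the compounds shown, and "the series" means these compounds.

Measured compounds in a functional assay on SKBR cells (Homo sapiens) for cytotoxicity, read by resazurin assay, with a stated time of 72 h; on this read-out higher numbers stand for weaker inhibition and lower numbers for stronger inhibition:
compound 1, `COc1cc(/C=C/C(=O)OCCCCCO[N+](=O)[O-])ccc1OCCCCCO[N+](=O)[O-]`, gives > 50000 nM, which is a limit of the assay.
compound 2, `COc1cc(/C=C/C(=O)OC/C=C/CO[N+](=O)[O-])ccc1O`, gives 6530 nM.
compound 3, `COc1cc(/C=C/C(=O)OCCCCCO[N+](=O)[O-])ccc1O`, gives 8060 nM.

Compound 3 has the highest of the two numbers given, with compound 2 close by, within the scatter. Going by the values given here, the only step measured is an at least 6.2-fold lower number from compound 1 to compound 3 (0.79 log units; beyond the scatter), a change on the aromatic oxygen, and compound 1 sits at the limit of > 50000 nM in this assay, at which 1 of the 3 values shown sits.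

Compound 4, `COc1cc(/C=C/C(=O)OCCCO[N+](=O)[O-])ccc1O`, differs from compound 3 in one place: nitrooxy in place of 2-(nitrooxy)ethyl on a saturated chain carbon, three bonds along the chain from an oxygen next to a carbonyl group. Among the compounds with values here, no measured step touches this chain, so nothing in the data points to a change beyond the scatter. Compound 4 is therefore expected to give about 8000 nM, between 3000 nM and 22000 nM. This estimate means a 1.0-fold lower number from compound 3 to compound 4 (0.00 log units; within the scatter), expected to lie within the scatter.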

Compound 4, half-maximal inhibitory concentration: 17200 nM
For compound 4 the middle estimate is 2.2-fold (0.33 log units) below the measured one; the measured number falls inside the stated range.
By their numbers in this assay, from the lowest: compounds 2 and 3 (each within the scatter of the next); then compound 4. At a limit, above all of these: compound 1.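

In this assay, this chain is not a silent position: putting nitrooxy in place of 2-(nitrooxy)ethyl gives a 2.1-fold higher number from compound 3 to compound 4 (0.33 log units; beyond the scatter). The group of 6 heavy atoms also compares unfavourably with the group of 7 heavy atoms, with a 2.6-fold higher number from compound 2 to compound 4 (0.42 log units; beyond the scatter). Nothing in the data accounts for either shift. As far as these compounds go, what stays open is whether a longer chain than 5-(nitrooxy)pentyl would lower the number further. From the compounds shown here alone, it also remains unknown how a hydroxyl or an amine in place of the terminal nitrooxy would behave.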